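Moving the hydroxyl across the ring: compound 3 to compound 4

This account rests on a few compounds, and the source may have more. Where it says the series, first, only, none or still open, it means among the compounds named here.

Among the compounds with values here, compound 3, with the structure `COc1cc(OC)cc(-c2cc3ccccc3c(-c3cccc(O)c3)n2)c1`, is the lowest of the three compounds measured so far; in an assay on isolated protein for inhibition of DNA topoisomerase 1 (Homo sapiens), with a stated time of 30 min, tested at 100 uM (on this read-out lower numbers stand for a weaker effect and higher numbers for a stronger effect at the one concentration tested), compound 3 gives 0%. Its nearest neighbour is compound 1, `COc1ccc(-c2cc3ccccc3c(-c3cccc(O)c3)n2)cc1`, which in this assay gives 9.4%, a gap within the scatter, while compound 2, `COc1ccc(-c2cc3ccccc3c(-c3cccc(OC)c3)n2)cc1`, gives 43.2%, a gap beyond the scatter. Within the data shown here, the only single step seen so far is a number 33.8 percentage points higher from compound 1 to compound 2 (beyond the scatter), brought about by methyl in place of hydrogen on an oxygen on an aromatic ring.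

Compound 4, `COc1cc(OC)cc(-c2cc3ccccc3c(-c3ccc(O)cc3)n2)c1`, has not yet been measured. It differs from compound 3 by 4-hydroxyphenyl in place of 3-hydroxyphenyl on an aromatic carbon. Among the measured compounds shown here, no measured step shows what happens when the hydroxyl is moved from the 3-hydroxyphenyl to the 4-hydroxyphenyl arrangement; the one step known concerns a different change. With nothing pointing either way, and compound 3 already at the bottom of the range, the expected step is a number 5 percentage points higher from compound 3 to compound 4 (within the scatter), that is, none beyond the scatter. Compound 4 is therefore estimated to give 5% in this assay, within a range from 0% to 20%.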

Compound 4, a percentage reported as inhibition, at one concentration (the size of the read-out at that concentration, not a potency): 0%
Compound 4: the middle estimate sits 5 percentage points above what was measured; the measured number falls inside the stated range.
By their numbers in this assay, from the lowest: compounds 3, 4 and 1 (each within the scatter of the next); then compound 2.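

Moving the hydroxyl from 3-hydroxyphenyl to 4-hydroxyphenyl, on the aromatic carbon next to the ring nitrogen, gives no change at the digits printed from compound 3 to compound 4 (within the scatter) in this assay. Earlier compounds showed only what a methyl on the oxygen can do; this pair adds that changing where the hydroxyl sits on this ring does not lift the number off the bottom of the range in this series. Nothing available bears on why the two compounds read alike.

With both compounds at the bottom of the range, this pair cannot tell whether the hydroxyl's place would matter in a compound with a higher number. Still open, on these data alone, is whether a methyl on the oxygen of compound 4 would bring a step like a number 33.8 percentage points higher from compound 1 to compound 2 (beyond the scatter), and whether an amine or a carboxylic acid in place of the hydroxyl would raise the number at all.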